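The compounds below may be only part of what the source reports. "The series", "measured", "known", "first", "only" and "open" are said of these compounds alone.

Measured compounds:
Compound 1 `c1ccc(C2=NN(c3ccc(-c4ccccc4)nn3)C(c3ccccc3)C2)cc1`: 23800 nM
Compound 2 `Clc1ccc(C2CC(c3ccccc3)=NN2c2ccc(-c3ccccc3)nn2)cc1`: 100000 nM

In a functional assay on MCF7 cells (Homo sapiens) for antiproliferative activity, read by MTT assay, with a stated time of 24 h (a higher number here means a weaker inhibitor, a lower number a stronger inhibitor), compound 2 gives the higher of the two numbers, standing a 4.2-fold higher number from compound 1 to compound 2 (0.62 log units; beyond the scatter); that step came from a chloro in place of hydrogen on an aromatic carbon. Compound 3 `Fc1ccc(C2CC(c3ccccc3)=NN2c2ccc(-c3ccccc3)nn2)cc1` differs from compound 2 by fluoro in place of chloro on an aromatic carbon. Among the compounds with values here, no measured step bears directly on swapping one halogen for another; the only step at hand shows that adding chloro weakened the compound, so the fluoro analogue is expected to fall between compound 1 and compound 2. Compound 3 is expected to give 60000 nM, in the range 20000 nM to 150000 nM, a step of a 1.7-fold lower number from compound 2 to compound 3 (0.22 log units; within the scatter).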

Compound 3, half-maximal inhibitory concentration: 100000 nM
Estimate against measurement, compound 3: 1.7-fold (0.22 log units) below; low and high end bracket the measured number.
By their numbers in this assay, from the lowest: compound 1; then compounds 2 and 3 (each within the scatter of the next).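

In this assay the change from 4-chlorophenyl to 4-fluorophenyl gives no change at the digits printed from compound 2 to compound 3 (within the scatter) and so does not separate these two halogens at this position. Fluoro in place of hydrogen gives a 4.2-fold higher number from compound 1 to compound 3 (0.62 log units; beyond the scatter) and matches the step seen with chloro, so the rise in the number here is not peculiar to chloro. No evidence is available to explain this result. The compounds shown leave open whether a non-halogen group at this position, such as an amine or a methoxy group, would lower the number below that of compound 1. They also leave open whether the same halogens would behave alike elsewhere on the shared core.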